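The source may report more compounds than this note shows. Statements on the series, on what has been measured and on what is new or still open speak of the compounds shown alone.

In a functional assay on A549 cells (Homo sapiens) for cytotoxicity, read by MTT assay, with a stated time of 48 h (a lower number here means a stronger inhibitor, a higher number a weaker inhibitor), compound 1 `COC(=O)[C@@H]1CCCN1C(=O)C1=C(C)NC(=S)NC1c1cccc(OCCCCCOc2cccc(C3NC(=S)NC(C)=C3C(=O)N3CCC[C@H]3C(=O)OC)c2)c1` gives 184 ug/mL. Compound 2 `CCOC(=O)C1=C(C)NC(=S)NC1c1ccc(OCCCCOc2ccc(C3NC(=S)NC(C)=C3C(=O)OCC)cc2OC)c(OC)c1` reads > 200 ug/mL, which is a limit of the assay and not a number. Compound 3 `CCOC(=O)C1=C(C)NC(=S)NC1c1ccc(OC/C=C\COc2ccc(C3NC(=S)NC(C)=C3C(=O)OCC)cc2OC)c(OC)c1` reads > 200 ug/mL, also a limit and not a number. Compound 3 therefore stands at the limit of > 200 ug/mL in this assay, at which 2 of the 3 values shown sit. Compound 4 `CCOC(=O)C1=C(C)NC(=S)NC1c1ccc(OC/C=C/COc2ccc(C3NC(=S)NC(C)=C3C(=O)OCC)cc2OC)c(OC)c1` relates to compound 3 by the two compounds have the same atoms and bonds; at least one stereo element is drawn with a configuration in one of them and without one in the other: 1 of 3 stereo elements differ; a double bond is drawn Z in compound 3 and E in compound 4; the two compounds have the same atoms and bonds, and a double bond is drawn Z in compound 3 and E in compound 4. Within the data shown here, no measured step speaks to this change, so no step beyond the scatter is expected in this assay, in either direction. The estimated step that the limit leaves unreadable from compound 3 to compound 4 is expected to stay within the scatter. For compound 4 the expected value is 220 ug/mL, with an estimated range of 140 ug/mL to 400 ug/mL.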

Compound 4, half-maximal inhibitory concentration: 165 ug/mL
Compound 4: the middle estimate sits 1.3-fold (0.12 log units) above what was measured, and the stated range covers the measured number.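

Among these compounds, the double bond's geometry is the first change with a readable step: in this assay, going from Z to E gives an at least 1.2-fold lower number from compound 3 to compound 4 (0.08 log units; that floor lies within the scatter). Compound 3 reads > 200 ug/mL, which is a limit of the assay and not a number. The true size of the step stays unread because of that limit, so no effect of the geometry is established: the limit of > 200 ug/mL in this assay, at which 2 of the 4 values shown sit.

Open, going by these compounds, is whether an alkyne in place of the double bond would move the reading out of this range. Also open, on these data alone, is what a free carboxylic acid or an amine in place of the ethyl ester would do.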